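Compound 3 to compound 4: working notes

The source may report more compounds than this note shows. Statements on the series, on what has been measured and on what is new or still open speak of the compounds shown alone.

Compound 3 `COc1ccc(Oc2ccccc2-c2ccsc2S(=O)(=O)N2CCN(C(=O)Nc3ccc([N+](=O)[O-])cc3)CC2)cc1OC` stands at > 50000 nM in a functional assay on RS4-11 cells (Homo sapiens) for inhibition, read by CCK-8 assay, with a stated time of 48 h (on this read-out higher numbers stand for weaker inhibition and lower numbers for stronger inhibition), and this is a limit of the assay, not a number.

Compound 4 `O=C(Nc1ccc([N+](=O)[O-])cc1)N1CCN(S(=O)(=O)c2sccc2-c2ccccc2Oc2ccc(O)c(O)c2)CC1` keeps the rest of compound 3 and differs by one change: 3,4-dihydroxyphenyl in place of 3,4-dimethoxyphenyl on an oxygen on an aromatic ring. The same difference reads 3,4-dimethoxyphenoxy to 3,4-dihydroxyphenoxy. Going by the values given here, no measured step covers this exchange directly. The 3,4-dihydroxyphenoxy group is present in compound 1 `O=C(Nc1cccc([N+](=O)[O-])c1)N1CCN(S(=O)(=O)c2sccc2-c2ccccc2Oc2ccc(O)c(O)c2)CC1`, which gives 9800 nM, and in compound 2 `O=C(Nc1ccc(F)cc1)N1CCN(S(=O)(=O)c2sccc2-c2ccccc2Oc2ccc(O)c(O)c2)CC1`, which gives 6800 nM. Among the compounds with values here, the one measured step, a 1.4-fold lower number from compound 1 to compound 2 (0.16 log units; within the scatter), lies within the scatter and concerns the group on the amide-type nitrogen, so compound 4 is expected to give a value in the same region despite differing from both at that nitrogen.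

In this assay, a clearly lower number, meaning stronger inhibition, is therefore expected, and the expected size is an at least 6.2-fold lower number from compound 3 to compound 4 (0.79 log units; beyond the scatter). For compound 4 the estimated value is 8000 nM, with an expected range from 3000 nM to 25000 nM.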

Compound 4, half-maximal inhibitory concentration: 14300 nM
Compound 4: the middle estimate sits 1.8-fold (0.25 log units) below what was measured; the range from low to high includes it.
By their numbers in this assay, from the lowest: compounds 2, 1 and 4 (each within the scatter of the next, the first and the last beyond it). At a limit, above all of these: compound 3.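

In this assay, going by these compounds alone, 3,4-dihydroxyphenyl in place of 3,4-dimethoxyphenyl on an oxygen on an aromatic ring gives an at least 3.4-fold lower number from compound 3 to compound 4 (0.54 log units; beyond the scatter), the first direct reading of this exchange with the rest of the structure held constant. Compound 3 stands at a limit of the assay, not a number, so this step gives only a minimum size: the limit of > 50000 nM in this assay, at which 1 of the 4 values shown sits. With the 3,4-dihydroxyphenoxy group kept, nitro in place of fluoro on an aromatic carbon gives a 2.1-fold higher number from compound 2 to compound 4 (0.32 log units; beyond the scatter), whereas swapping the 3-nitrophenyl group for the 4-nitrophenyl group at the amide-type nitrogen gives a 1.5-fold higher number from compound 1 to compound 4 (0.16 log units; within the scatter).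

From the compounds shown here alone, it remains open whether a single hydroxyl, or an amine or a carboxylic acid on the same ring, would give a value like that of compound 4. Going by these compounds, the 3,4-dimethoxyphenoxy group appears only in compound 3, so whether the exchange holds with 4-fluorophenyl or 3-nitrophenyl on the amide-type nitrogen also remains open.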